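Swapping the aryl group on the shared five-membered ring

This account rests on a few compounds, and the source may have more. Where it says the series, first, only, none or still open, it means among the compounds named here.

Measured so far:
Compound 1, `Cc1cccc(-c2nc(C)c(COc3ccc4c(c3)OCC4CC(=O)O)s2)c1`, 47.2%
Compound 2, `Cc1ccc(-c2nc(C)c(COc3ccc4c(c3)OCC4CC(=O)O)s2)cc1`, 54.9%

Both were tested in a functional assay on CHO cells for agonist activity at Free fatty acid receptor 1 (Homo sapiens), read by FLIPR and calcium flux, tested at 100 nM; a higher number here means a stronger effect of the compound at the concentration tested, a lower number a weaker effect. Compound 2 has the highest of the two numbers, but its nearest neighbour compound 1 is only a number 7.7 percentage points higher from compound 1 to compound 2 (within the scatter), so the two cannot be told apart.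

Compound 3, `Cc1nc(-c2ccccc2Cl)sc1COc1ccc2c(c1)OCC2CC(=O)O`, has not yet been measured. It differs from compound 2 in one place: 2-chlorophenyl in place of 4-methylphenyl on an aromatic carbon. Among the compounds with values here, the only measured step, a number 7.7 percentage points higher from compound 1 to compound 2 (within the scatter), moved a methyl around the phenyl ring and stayed within the scatter; no measured step exchanges the methyl for chlorine, so nothing bears directly on this change. The expectation is therefore a step of about a number 6.9 percentage points lower from compound 2 to compound 3 (within the scatter), i.e. none beyond the scatter, with wide uncertainty. Compound 3 is estimated at 48%, in the range 25% to 70%.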

Compound 3, a percentage reported as activity, at one concentration (the size of the read-out at that concentration, not a potency): 12.4%
Compound 3: middle estimate off by 35.6 percentage points, on the high side; measured number outside the range, below it.
By their numbers in this assay, from the lowest: compound 3; then compounds 1 and 2 (each within the scatter of the next).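

In this assay the change to 2-chlorophenyl gives a number 42.5 percentage points lower from compound 2 to compound 3 (beyond the scatter) and a number 34.8 percentage points lower from compound 1 to compound 3 (beyond the scatter) and so shows that the aryl group on this carbon, next to the ring nitrogen and the ring sulfur, can strongly affect the read-out. The earlier step between compound 1 and compound 2 stayed within the scatter and gave no sign of this. The groups that leave and the group that enters have the same heavy-atom count and the same kind of aromatic ring, and nothing shown here explains the loss.

The change replaces methyl with chlorine and also alters the group's place on the phenyl ring, and these compounds cannot separate the two. Going by these compounds, neither 2-methylphenyl nor 4-chlorophenyl is among them, so it remains open whether the chlorine, its place on the ring, or the combination lies behind the fall.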